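The source may report more compounds than this note shows. Statements on the series, on what has been measured and on what is new or still open speak of the compounds shown alone.

In a functional assay on Jurkat cells (Homo sapiens) for antiproliferative activity, read by MTT assay, with a stated time of 72 h (on this read-out lower numbers stand for stronger inhibition and higher numbers for weaker inhibition), compound 3 `CCOc1ccc(-c2sc(NC)nc2-c2cc(OC)c(OC)c(OC)c2)cc1` gives 1.7 nM and compound 2 `CNc1nc(-c2cc(OC)c(OC)c(OC)c2)c(-c2ccc(C(F)(F)F)cc2)s1` gives 3010 nM on the same core, while compound 1 `CNc1nc(-c2cc(OC)c(OC)c(OC)c2)c(-c2ccc3ccccc3c2)s1` at 51.1 nM stands between them, second highest of the three numbers. Compound 4 `COc1cc(-c2nc(N(C)C)sc2-c2ccc3ccccc3c2)cc(OC)c1OC` has not yet been measured. It differs from compound 1 by methyl in place of hydrogen on a nitrogen on an aromatic ring with methyl in place of hydrogen on a nitrogen on an aromatic ring, which turns methylamino to dimethylamino. For the measured compounds named here, the single measured step of a 1800-fold lower number from compound 2 to compound 3 (3.25 log units; beyond the scatter) is large, yet it is ethoxy in place of trifluoromethyl on an aromatic carbon and does not touch that nitrogen. Going by the values given here, it shows that one change can move the numbers in this assay a long way in this small set, but no measured compound tests the nitrogen. The expectation is therefore a judgement: a moderate step to a higher number, meaning weaker inhibition, and well short of the step between compound 2 and compound 3. The expected step is a 6.8-fold higher number from compound 1 to compound 4 (0.84 log units; beyond the scatter) with wide uncertainty. The expected value for compound 4 is 350 nM with 70 nM to 2500 nM as its range.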

Compound 4, half-maximal inhibitory concentration: 836 nM
For compound 4 the middle estimate is 2.4-fold (0.38 log units) below the measured one, and the stated range covers the measured number.
By their numbers in this assay, from the lowest: compound 3; then compound 1; then compound 4; then compound 2.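

The nitrogen now has a measured test: in this assay, replacing the hydrogen on this nitrogen with methyl, which turns methylamino to dimethylamino, gives a 16-fold higher number from compound 1 to compound 4 (1.21 log units; beyond the scatter). For the compounds shown here, until this result, the only single-place step available, a 1800-fold lower number from compound 2 to compound 3 (3.25 log units; beyond the scatter), concerned a group on an aromatic carbon, so the shared nitrogen stood untested; it is now clear that this position, too, responds to a change of a single methyl, and that the change here weakens inhibition. Nothing measured here accounts for the size of this step.

As far as these compounds go, this step is read only with the core of compound 1, so whether it would hold alongside the ethoxy group of compound 3 remains open. The compounds shown also leave open how a free amino group, an ethyl group or a longer chain on that nitrogen would compare.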